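Isopropyl on the Amidine Nitrogen, Repeated on a Second Core

A few compounds are considered here, and "the series" means these few. Any claim that something is new, unique, unknown or untested is made for them only; others in the source may bear on it.

Measured compounds:
compound 1, `N=C(N)c1ccc2oc(-c3cccc(OCCCOc4ccccc4)c3)cc2c1`: 10300 nM
compound 2, `CC(C)NC(=N)c1ccc2oc(-c3cccc(OCCCOc4ccccc4)c3)cc2c1`: 26500 nM
compound 3, `N=C(N)c1ccc2cc(-c3ccc(OCCCCOc4ccccc4)cc3)oc2c1`: 14100 nM

All three compounds were tested in an ADME assay on L6 cells (Rattus norvegicus) for cytotoxicity, read by resazurin assay, with a stated time of 70 h; a higher number here means a weaker inhibitor, a lower number a stronger inhibitor. Compound 1 and compound 2 share a core and differ only by isopropyl in place of hydrogen on an amine nitrogen; this change gave a 2.6-fold higher number from compound 1 to compound 2 (0.41 log units; beyond the scatter). Compound 3 is built on a different core, and the difference between the core of compound 1 and the core of compound 3 is not broken down here. In this assay compound 3 gives 14100 nM, which lies within the scatter of compound 1 and within the scatter of compound 2.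

Compound 4, `CC(C)NC(=N)c1ccc2cc(-c3ccc(OCCCCOc4ccccc4)cc3)oc2c1`, is not yet measured. It differs from compound 3 by isopropyl in place of hydrogen on an amine nitrogen, the same change that turns compound 1 into compound 2, at a place described in the same words. For the measured compounds named here, the step from compound 3 to compound 4 is expected to be a 2.3-fold higher number from compound 3 to compound 4 (0.37 log units; beyond the scatter), of about the size seen in a 2.6-fold higher number from compound 1 to compound 2 (0.41 log units; beyond the scatter), because a 2.6-fold higher number from compound 1 to compound 2 (0.41 log units; beyond the scatter) is the only measured instance of this change. On that basis compound 4 is expected to give 33000 nM, with a likely range from 18000 nM to 60000 nM.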

Compound 4, half-maximal inhibitory concentration: 15900 nM
The estimate for compound 4 lay 2.1-fold (0.32 log units) above the measured number; measured number below the stated range.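

On the second core, isopropyl in place of hydrogen on an amine nitrogen gave a 1.1-fold higher number from compound 3 to compound 4 (0.05 log units; within the scatter) in this assay, so this step does not rise above the usual variation between repeated measurements. Set beside the earlier step, it cannot be told apart from it: the same change on two cores in this assay, a 2.6-fold higher number (0.41 log units; beyond the scatter) from compound 1 to compound 2 and a 1.1-fold higher number (0.05 log units; within the scatter) from compound 3 to compound 4, 2.3-fold (0.36 log units) apart, within the scatter of two such steps. The two steps are therefore compatible with a single effect of this change on both cores, but they do not show that the change carries over at a fixed size, and they do not rule out that its size depends on the core.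

The compounds shown leave open whether a different group on the amine nitrogen, such as methyl or cyclopentyl, would give similar steps on these two cores. They also leave open how isopropyl would behave on a core with a longer chain than those in compound 1 and compound 3.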